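A few compounds are considered here, and "the series" means these few. Any claim that something is new, unique, unknown or untested is made for them only; others in the source may bear on it.

Compound 1 `CCOc1ccc(-c2c(C#N)c(N)nc(SCc3ccn[nH]3)c2C#N)cc1`: 18%
Compound 2 `N#Cc1c(N)nc(SCc2ncn[nH]2)c(C#N)c1-c1ccc(OCC2CC2)cc1`: 1%
Compound 3 `CNC(=O)CSc1nc(N)c(C#N)c(-c2ccc(OCC3CC3)cc2)c1C#N`: 3%

All three were tested in an assay on CHO cells for displacement of a labelled ligand from adenosine receptor A3 (Homo sapiens), read by scintillation counting, with a stated time of 120 min, tested at 1 uM; on this read-out higher numbers stand for more inhibition at the one concentration tested (going by the name of the read-out) and lower numbers for less inhibition. Compound 3 gives 3%, the second highest of the three numbers. Its nearest neighbour is compound 2 with 1%, and the gap between the two lies within the usual scatter, so no order can be read from it. Compound 1, with 18%, stands further away, by a gap beyond the scatter.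

The next compound, compound 4 `N#Cc1c(N)nc(SCC2=NCCN2)c(C#N)c1-c1ccc(OCC2CC2)cc1`, has not yet been measured in this assay. It differs from compound 3 in one place: a group of 5 heavy atoms (3 carbon, 2 nitrogen; one five-membered non-aromatic ring with 2 hetero atoms) in place of a group of 4 heavy atoms (2 carbon, 1 nitrogen, 1 oxygen; no ring), on a saturated chain carbon bound to a sulfur. Among the measured compounds shown here, only one measured step bears on this position, namely a number 2 percentage points higher from compound 2 to compound 3 (within the scatter), where one small group on the same chain carbon was traded for another without moving the number beyond the scatter. On that single precedent, the exchange in compound 4 is expected to leave this assay much where compound 3 stands, with no step beyond the scatter.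

Compound 4 is therefore estimated at 6%, in a range from 0% to 20%, which amounts to an expected step of a number 3 percentage points higher from compound 3 to compound 4 (within the scatter).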

Compound 4, a percentage reported as inhibition, at one concentration (the size of the read-out at that concentration, not a potency): 6%
Compound 4: the middle estimate sits on the measured number at the digits printed; the range from low to high includes it.
By their numbers in this assay, from the lowest: compounds 2, 3 and 4 (each within the scatter of the next); then compound 1.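

In this assay, putting the five-membered non-aromatic ring with 2 hetero atoms in place of methylcarbamoyl, on the saturated chain carbon bound to a sulfur, gives a number 3 percentage points higher from compound 3 to compound 4 (within the scatter), and putting it in place of the five-membered aromatic ring at that same carbon gives a number 5 percentage points higher from compound 2 to compound 4 (within the scatter). Among the compounds shown here, this position has now carried a group with no ring, an aromatic ring and a non-aromatic ring, and none of the three exchanges among them moves the number beyond the scatter, something the single earlier step could not show for a ring that is not aromatic. No measurement on these compounds offers an explanation for this sameness.

On these data alone, whether the flat picture holds for quite different groups at this carbon, such as a carboxylic acid, a primary amine or a longer chain ending in one of these rings, remains open. Compound 1 (18%) differs from the other compounds in more than one place, so its number cannot be tied to any single group, and a single exchange on its ether side chain or on its ring would be needed to separate the two.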